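Adding a Methyl Group to the Phenoxy Ring

The source may report more compounds than this note shows. Statements on the series, on what has been measured and on what is new or still open speak of the compounds shown alone.

Compound 1, `Cc1ccc(NC(=O)COc2ccccc2)c(C(N)=O)c1`, was tested in a functional assay on K562 cells (Homo sapiens) for inhibition, read by trypan blue exclusion, with a stated time of 24 h, tested at 10 uM (on this read-out lower numbers stand for less inhibition of growth and higher numbers for more inhibition of growth at the one concentration tested), and gives 72%. Compound 2, `Cc1ccc(OCC(=O)Nc2ccc(C)cc2C(N)=O)cc1`, differs from it by methyl in place of hydrogen on an aromatic carbon and gives 30.3% in this assay; this step, a number 41.7 percentage points lower from compound 1 to compound 2 (beyond the scatter), is the one to keep in view. Compound 3, `COc1ccc(NC(=O)COc2ccccc2)c(C(N)=O)c1`, carries a different core, differing from compound 1 by methoxy in place of methyl on an aromatic carbon; in this assay compound 3 gives 85.3%; the step of a number 13.3 percentage points higher from compound 1 to compound 3 (beyond the scatter) is modest. Compound 4, `COc1ccc(NC(=O)COc2ccccc2C)c(C(N)=O)c1`, has not yet been measured; it differs from compound 3 by methyl in place of hydrogen on an aromatic carbon. This is the same kind of change as that from compound 1 to compound 2, but not the same: in compound 2 the methyl sits para to a large group, in compound 4 ortho to a large group. Among the compounds with values here, only one earlier example exists, on another core and at another place, so the expectation rests on a single step. Compound 4 is expected to fall by the step of a number 30.3 percentage points lower from compound 3 to compound 4 (beyond the scatter) because the earlier addition gave a number 41.7 percentage points lower from compound 1 to compound 2 (beyond the scatter). The estimate for compound 4 is 55%, with a range from 30% to 80%.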

Compound 4, percent growth inhibition at one concentration: 40.1%
Beside the measured number, compound 4's estimate is 14.9 percentage points above it; the measured number falls inside the stated range.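

In this assay, the change from phenyl to 2-methylphenyl gives a large loss of growth inhibition, a number 45.2 percentage points lower from compound 3 to compound 4 (beyond the scatter), and this matches the same addition on the core of compound 1: the same change on two cores in this assay, a number 41.7 percentage points lower (beyond the scatter) from compound 1 to compound 2 and a number 45.2 percentage points lower (beyond the scatter) from compound 3 to compound 4, 3.5 percentage points apart, within the scatter of two such steps Across these two pairs, then, adding a methyl group to this ring carries over from one core to the other with much the same size of loss, whether the other ring bears methyl or methoxy. Within the data shown here, this does not make a general rule, since it rests on only two pairs at a single concentration in a single cell line, the methyl in compound 4 sits ortho to a large group while the one in compound 2 sits at another place on the ring, and nothing here explains why growth inhibition falls.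

The compounds shown leave open whether the loss belongs to the methyl group itself or would also follow other groups on this ring, such as a fluorine atom, a hydroxyl group or an amine. They also leave open whether a third core would show a step of the same size.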